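Hydroxy in place of aminoamino: expected paw edema inhibition

The source may hold more compounds than are shown below. What is called first, only, known or untested is meant among the compounds shown, and "the series" means these compounds.

Compound 2 `NNc1nn2cnnc2c2c1sc1c(Br)cccc12` gives 52.8% in a functional assay on the whole organism (strain albino) for inhibition, with Rattus norvegicus as the target, read by paw edema, with stated times of 1 h and 3 h, at a dose of 10 mg/kg by the oral route (a lower number here means less inhibition, a higher number more inhibition at the dose given (going by the name of the read-out)), the second highest of the three numbers; compound 3 `COc1ccccc1-c1nnc2c3c(sc4c(Br)cccc43)c(NN)nn12` gives 78.7% and compound 1 `COc1ccccc1-c1nnc2c3c(sc4c(Br)cccc43)c(N3CCCCC3)nn12` gives 8.4%. Compound 4 `Oc1nn2cnnc2c2c1sc1c(Br)cccc12` differs from compound 2 by hydroxy in place of aminoamino on an aromatic carbon. Going by the values given here, the one measured step at the same aromatic carbon, a number 70.3 percentage points higher from compound 1 to compound 3 (beyond the scatter), shows that the group at this place moves the read-out strongly, while a number 25.9 percentage points higher from compound 2 to compound 3 (beyond the scatter) concerns another place and bears only indirectly. Both higher numbers belong to compounds carrying aminoamino; compound 4 lacks it. A fall is therefore expected for compound 4, estimated at a number 24.8 percentage points lower from compound 2 to compound 4 (beyond the scatter). Compound 4 is expected to give 28%, in the range 5% to 52%.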

Compound 4, a percentage reported as inhibition, in the whole organism at one dose (the size of the read-out at that dose, not a potency): 9.7%
For compound 4 the middle estimate is 18.3 percentage points above the measured one; the range from low to high includes it.
By their numbers in this assay, from the lowest: compounds 1 and 4 (each within the scatter of the next); then compound 2; then compound 3.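

In this assay, the step of a number 43.1 percentage points lower from compound 2 to compound 4 (beyond the scatter) shows that on the core without 2-methoxyphenyl, loss of aminoamino at this aromatic carbon also costs a large part of the read-out. With a number 70.3 percentage points higher from compound 1 to compound 3 (beyond the scatter), aminoamino now gives the higher number in both single-place comparisons at this carbon, with no listed compound against it. The two replacements differ widely, since hydroxy has fewer heavy atoms than aminoamino and piperidin-1-yl is a ring.

Open, on these data alone, is whether a plain amine or methylamino at this carbon keeps the read-out, and what hydroxy does alongside 2-methoxyphenyl. Nothing available explains the fall.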